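The source may hold more compounds than are shown below. What is called first, only, known or untested is meant among the compounds shown, and "the series" means these compounds.

Compound 1, `COc1ccc(N(C)c2nccc(-c3ccncc3)n2)cc1`: in a functional assay for inhibition, with Homo sapiens as the target (a lower number here means a stronger inhibitor, a higher number a weaker inhibitor), compound 1 gives > 24000 nM, a limit.
Compound 2, `COc1ccc(N(C)c2nccc(-c3cccnc3)n2)cc1`: in this assay compound 2 gives > 24000 nM, a limit.
Compound 3, `CN(C)c1ccc(Nc2nccc(-c3cccnc3)n2)cc1`: in this assay compound 3 gives 2800 nM.

Within the data shown here, compound 3 is the only one with a number; the other two values are the limit of > 24000 nM in this assay, at which 2 of the 3 values shown sit. From compound 2 to compound 1 the change is pyridin-4-yl in place of pyridin-3-yl on an aromatic carbon, and the step is a step that the two limits leave unreadable from compound 2 to compound 1. Compound 4, `CN(C)c1ccc(Nc2nccc(-c3ccncc3)n2)cc1`, is not yet measured; it carries the same change from compound 3, (pyridin-4-yl in place of pyridin-3-yl on an aromatic carbon). The difference between the core of compound 3 and the core of compound 2 is not broken down here. Because a step that the two limits leave unreadable from compound 2 to compound 1 gives no readable size, the step from compound 3 to compound 4 in this assay is expected to be small but uncertain, a 1.3-fold higher number from compound 3 to compound 4 (0.10 log units; within the scatter). Compound 4 is expected to give 3500 nM, estimated between 900 nM and 14000 nM.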

Compound 4, half-maximal inhibitory concentration: 3700 nM
Compound 4: the middle estimate sits 1.1-fold (0.02 log units) below what was measured; the measured number falls inside the stated range.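

In this assay, pyridin-4-yl in place of pyridin-3-yl on the core of compound 3 gives a 1.3-fold higher number from compound 3 to compound 4 (0.12 log units; within the scatter), so on this core the two pyridine attachments cannot be told apart. The same change on the core of compound 2 cannot be read, because compound 1 and compound 2 both sit at a limit: the limit of > 24000 nM in this assay, at which 2 of the 4 values shown sit.

Among these compounds, with only one readable step, this does not show that the change carries from one core to another, only that it is tolerated on the core of compound 3. The compounds shown leave open what an amine or a carboxylic acid in place of the pyridin-4-yl would give in this assay. They also leave open whether this change would give a readable step on any core other than that of compound 3.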